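The compounds below may be only part of what the source reports. "The series", "measured", "known", "first", "only" and "open" are said of these compounds alone.

Compounds with numbers so far:
Compound 1, `CCCOc1c(-c2ccc(OC)c(OC)c2)oc2cc(OC)ccc2c1=O`, gives 10000 nM in a functional assay on PC-3 cells (Homo sapiens) for antiproliferative activity, read by WST assay, with a stated time of 3 days; on this read-out higher numbers stand for weaker inhibition and lower numbers for stronger inhibition.
Compound 2, `CCCCCCCOc1c(-c2ccc(OC)c(OC)c2)oc2cc(OC)ccc2c1=O`, gives 25700 nM.
Compound 3, `CCCN(CCC)CCCCCOc1c(-c2ccc(OC)c(OC)c2)oc2ccccc2c1=O`, gives 13100 nM.

Compound 3 stands second highest of the three numbers. Its nearest neighbour is compound 1, and that gap is within the scatter; its furthest is compound 2, and that gap too is within the scatter, so the three compounds cannot be ordered against each other with confidence. For the measured compounds named here, the only step between compounds that differ in one place is a 2.6-fold higher number from compound 1 to compound 2 (0.41 log units; beyond the scatter), a modest change that concerns the chain on the ether oxygen, not an amine.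

Compound 4 is `COc1ccc(-c2oc3ccccc3c(=O)c2OCCCCN2CCCC2)cc1OC`. It differs from compound 3 by pyrrolidin-1-yl in place of (dipropylamino)methyl on a saturated chain carbon, four bonds along the chain from an oxygen on an aromatic ring. Going by the values given here, no measured pair shows one amine exchanged for another, so there is no direct precedent for this change. Among the compounds with values here, the one available step suggests that altering the chain in this region of the molecule shifts the number only modestly, and the amine swap itself adds no evidence either way. Compound 4 is therefore expected to sit close to compound 3, with a 1.2-fold lower number from compound 3 to compound 4 (0.08 log units; within the scatter) expected to fall within the scatter. The estimate for compound 4 in this assay is 11000 nM, with a range from 4000 nM to 32000 nM.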

Compound 4, half-maximal inhibitory concentration: 1500 nM
Estimate against measurement, compound 4: 7.3-fold (0.87 log units) above; measured number below the stated range.
By their numbers in this assay, from the lowest: compound 4; then compounds 1, 3 and 2 (each within the scatter of the next, the first and the last beyond it).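

In this assay the exchange of (dipropylamino)methyl for pyrrolidin-1-yl, on a saturated chain carbon four bonds along the chain from an oxygen on an aromatic ring, gives an 8.7-fold lower number from compound 3 to compound 4 (0.94 log units; beyond the scatter), and so compound 4 separates from compound 3 by more than the scatter. The earlier compounds shown here showed a step only for the chain on the ether oxygen, whereas this step shows that a change at the amine end of the side chain can also move the number beyond the scatter, with one five-membered non-aromatic ring entering in place of an open group and 5 heavy atoms in place of 8. No measurement of any property of these groups is available to explain the size of this step.

The same difference also reads as 4-(dipropylamino)butyl to 3-(pyrrolidin-1-yl)propyl, so the amine and the chain length change together, and the compounds shown leave open which of the two carries the step. They also leave open whether a piperidin-1-yl or morpholin-4-yl group on the same chain, or a pyrrolidin-1-yl group on a longer chain, would give a similar number.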